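Removing an Amino Group from a Thione Analogue

A few compounds are considered here, and "the series" means these few. Any claim that something is new, unique, unknown or untested is made for them only; others in the source may bear on it.

Measured so far:
compound 1, `COc1cc2c(cc1OC)C(c1cccc(N)c1)=NN=C(S)C2`, 9.1 umol/kg
compound 2, `COc1cc2c(cc1OC)C(c1ccccc1)=NNC(=O)C2`, 31.8 umol/kg
compound 3, `COc1cc2c(cc1OC)C(c1ccc(Br)cc1)=NNC(=O)C2`, 82.5 umol/kg

In a functional assay on the whole organism with Mus musculus as the target (a higher number here means that more compound is needed for the effect, a lower number that less compound is needed), compound 1 gives the lowest of the three numbers; compound 2 sits above it and compound 3 furthest above it. Among the compounds with values here, the one measured step, a 2.6-fold higher number from compound 2 to compound 3 (0.41 log units; beyond the scatter), concerns a different change on the shared core with a carbonyl rather than the thione of compound 1.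

Compound 4, `COc1cc2c(cc1OC)C(c1ccccc1)=NN=C(S)C2`, differs from compound 1 by hydrogen in place of amino on an aromatic carbon. Within the data shown here, no measured step covers this change, so the direction is uncertain. A modest rise in this assay is expected for compound 4, a 1.8-fold higher number from compound 1 to compound 4 (0.25 log units; within the scatter), giving an estimated 16 umol/kg with a range from 6 umol/kg to 45 umol/kg.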

Compound 4, dose for half-maximal effect: 15 umol/kg
Estimate against measurement, compound 4: 1.1-fold (0.03 log units) above; low and high end bracket the measured number.
By their numbers in this assay, from the lowest: compounds 1 and 4 (each within the scatter of the next); then compound 2; then compound 3.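

Replacing amino with hydrogen on the aromatic ring gives a 1.6-fold higher number from compound 1 to compound 4 (0.22 log units; within the scatter) in this assay, so 3-aminophenyl and phenyl cannot be told apart here. The amino group is therefore not needed for the effect on this thione core, something the earlier carbonyl pair, which differs only by bromo, could not show. Nothing available explains why this swap leaves the number within the scatter.

On these data alone, it remains open how a carboxylic acid or an acetamide at this place would read. As far as these compounds go, whether the same swap would behave alike on the carbonyl core also remains open.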